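Cytotoxicity notes on the series: methoxy in place of cyano

The source may report more compounds than this note shows. Statements on the series, on what has been measured and on what is new or still open speak of the compounds shown alone.

Measured compounds:
Compound 1 `N#Cc1ccc(NCc2cncn2Cc2ccc(-c3ccccc3)cc2N)cc1-c1ccccc1`: > 1000 nM
Compound 2 `N#Cc1ccc(NCc2cncn2Cc2ccc(-c3ccccc3)cc2)cc1-c1ccccc1`: > 1000 nM
Compound 3 `c1ccc(Cn2cncc2CNc2cccc(-c3ccncc3)c2)cc1`: > 1000 nM

In a toxicity assay on NIH3T3 cells (Mus musculus) for cytotoxicity, read by resazurin assay (a higher number here means that more compound is needed for the effect, a lower number that less compound is needed), compound 1 gives only a limit, > 1000 nM. In this assay compound 2 likewise gives only a limit, > 1000 nM. Compound 3 also gives only a limit, > 1000 nM. Compound 2 therefore stands at the same limit as every other measured value, as the limit of > 1000 nM in this assay, at which 3 of the 3 values shown sit, records. Among the measured compounds shown here, the single measured step that changes one place, hydrogen in place of amino on an aromatic carbon, is a step that the two limits leave unreadable from compound 1 to compound 2; both of its ends are limits, so its size cannot be read.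

Compound 4 `COc1ccc(NCc2cncn2Cc2ccc(-c3ccccc3)cc2)cc1-c1ccccc1` differs from compound 2 by methoxy in place of cyano on an aromatic carbon. For the measured compounds named here, no measured step bears on this exchange: the only step in the set concerns the amino group and is unreadable, and the cyano group is never varied among the measured compounds. With every measured value at the limit, the expected step is a step that the limit leaves unreadable from compound 2 to compound 4, i.e. no change beyond the scatter. For compound 4 the estimate in this assay is 3000 nM, with a range from 1000 nM to 20000 nM, and the result is expected most likely to be reported again only as a limit.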

Compound 4, half-maximal effective concentration: > 1000 nM
Compound 4: no number, only a limit; the forecaster's own chance of this, stated with the estimate: 85%; the middle value is on the limit's open side.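

No new step can be read: compound 2 and compound 4 both give only limits, so the exchange of cyano for methoxy has no readable size. The compounds shown leave open where any of the four would give an actual number for cytotoxicity.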